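Biaryl ring returns on the isobutyl side chain

This account rests on a few compounds, and the source may have more. Where it says the series, first, only, none or still open, it means among the compounds named here.

In a functional assay for agonist activity at G protein-coupled receptor 88 (Homo sapiens), read by HTRF and cAMP accumulation (on this read-out higher numbers stand for an effect only at larger amounts of compound and lower numbers for an effect already at smaller amounts), compound 1 `CC(C)(C)[C@H](N)CN(C(=O)[C@@H]1C[C@H]1c1ccccc1)c1ccc(-c2ccccc2)cc1` gives 11 nM. Compound 2 `CC[C@H](C)[C@H](N)CN(C(=O)[C@@H]1C[C@H]1c1cccc(C#N)c1)c1ccc(-c2ccccc2)cc1` gives 1600 nM in this assay, and compound 3 `CC(C)C[C@H](N)CN(C(=O)[C@@H]1C[C@H]1c1ccccc1)c1ccc(C2=CCCCC2)cc1` gives 1200 nM. Compound 3 therefore holds the second highest of the three numbers; the number of compound 2 lies within the scatter of it, whereas compound 1 sits beyond the scatter at the low end. Compound 4 `CC(C)C[C@H](N)CN(C(=O)[C@@H]1C[C@H]1c1ccccc1)c1ccc(-c2ccccc2Cl)cc1` differs from compound 3 by 2-chlorophenyl in place of cyclohex-1-en-1-yl on an aromatic carbon. Among the compounds with values here, no measured pair shows this change on its own, so the expectation rests on compound 1 alone, which carries an aromatic ring at this place and gives 11 nM, though compound 2 with the same ring type gives 1600 nM. A downward step of moderate size, a 6.0-fold lower number from compound 3 to compound 4 (0.78 log units; beyond the scatter), is expected. Compound 4 is estimated at 200 nM, within 40 nM to 1000 nM.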

Compound 4, half-maximal effective concentration: 3800 nM
Compound 4: the middle estimate sits 19-fold (1.28 log units) below what was measured; the measured number lies above the stated range.
By their numbers in this assay, from the lowest: compound 1; then compounds 3 and 2 (each within the scatter of the next); then compound 4.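

On the isobutyl side chain, an aromatic ring at this place does not by itself lower the number: in this assay, 2-chlorophenyl in place of cyclohex-1-en-1-yl gives a 3.2-fold higher number from compound 3 to compound 4 (0.50 log units; beyond the scatter) on this core. Compound 1 differs from compound 4 in more than one place, so its low number cannot be assigned to the aromatic ring alone. Nothing available here accounts for this step.

Still open, on these data alone, is how unsubstituted phenyl, 2-fluorophenyl or 2-methoxyphenyl would read at this place, and whether the step holds with the side chain of compound 1.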